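Replacing a Lactam Acyl Group with an Arylsulfonyl Group

A few compounds are considered here, and "the series" means these few. Any claim that something is new, unique, unknown or untested is made for them only; others in the source may bear on it.

Results so far in a functional assay on MDA-MB-231 cells (Homo sapiens) for antiproliferative activity, read by MTT assay, with a stated time of 24 h; on this read-out higher numbers stand for weaker inhibition and lower numbers for stronger inhibition

- Compound 1 (`O=C(c1cc(Cl)ccn1)N1CCN(c2nccc(Oc3cc(Cl)cc(Cl)c3)n2)CC1`) gives 16700 nM
- Compound 2 (`O=C1CC[C@@H](C(=O)N2CCN(c3nccc(Oc4cc(Cl)cc(Cl)c4)n3)CC2)N1`) gives > 50000 nM as a limit, not a number
- Compound 3 (`COc1ccccc1S(=O)(=O)N1CCN(c2nccc(Oc3cc(Cl)cc(Cl)c3)n2)CC1`) gives 16800 nM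
- Compound 4 (`O=S(=O)(c1ccc(F)cc1)N1CCN(c2nccc(Oc3cc(Cl)cc(Cl)c3)n2)CC1`) has not yet been measured

Compound 2 stands at the limit of > 50000 nM in this assay, at which 1 of the 3 values shown sits, and therefore has only a limit rather than a number. Moving to compound 4 exchanges (5-oxopyrrolidin-2-yl)carbonyl for (4-fluorophenyl)sulfonyl on an amine nitrogen in a ring, and the full count is (4-fluorophenyl)sulfonyl in place of (5-oxopyrrolidin-2-yl)carbonyl on an amine nitrogen in a ring as computed from the two structures.

One measured step involves the group that leaves. It is an at least 2.9-fold higher number from compound 1 to compound 2 (0.47 log units; beyond the scatter) and lies beyond the scatter, and its true size could be larger since one end is a limit. Removing that group should therefore lower the number, meaning stronger inhibition in this assay by a step of at least similar size.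

The closest guide is compound 3, which also carries an aromatic ring through a sulfonyl group on that nitrogen and gives 16800 nM as a real number. For the measured compounds named here, no step links it directly to compound 4, so the expectation stays broad.

The estimated change is an at least 3.1-fold lower number from compound 2 to compound 4 (0.49 log units; beyond the scatter) towards stronger inhibition.

For compound 4 the expected value is 16000 nM with an estimated range from 7000 nM to 40000 nM as the likely span.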

Compound 4, half-maximal inhibitory concentration: > 50000 nM
Compound 4 was reported as a limit; the forecaster's own chance of this, stated with the estimate: 12%; middle value at least 3.1-fold (0.49 log units) away from the limit.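

In this assay, an aromatic ring on a sulfonyl group at the ring nitrogen does not by itself keep a readable value: 4-fluorophenyl in place of 2-methoxyphenyl on the sulfonyl sulfur gives an at least 2.9-fold higher number from compound 3 to compound 4 (0.47 log units; beyond the scatter). So the group on the sulfur matters at this position, which the earlier compounds could not show, as only one sulfonyl compound had been measured. The sulfonyl compound with 4-fluorophenyl also falls behind the amide that carries 4-chloropyridin-2-yl, with (4-fluorophenyl)sulfonyl in place of (4-chloropyridin-2-yl)carbonyl giving an at least 2.9-fold higher number from compound 1 to compound 4 (0.47 log units; beyond the scatter), while the step between the lactam amide and this sulfonyl compound cannot be read, as compound 2 and compound 4 both rest on a limit and not on a number: the limit of > 50000 nM in this assay, at which 2 of the 4 values shown sit.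

From the compounds shown here alone, compound 3 and compound 4 differ in both the substituent and its place on the phenyl ring, so it stays open whether the fluorine or the methoxy group accounts for the step. Going by these compounds, it also stays open how a phenyl ring on the sulfonyl group bearing an amine or a carboxylic acid would read in this assay.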